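A few compounds are considered here, and "the series" means these few. Any claim that something is new, unique, unknown or untested is made for them only; others in the source may bear on it.

Compound 1 `CN1CC2(C1)CN(c1ccc(OCc3ccccc3)c(C(=O)Nc3ccnnc3)c1)C2`: 25.1 nM
Compound 2 `O=C(Nc1ccnnc1)c1cc(N2CCNCC2)ccc1OCc1ccccc1`: 15.9 nM
Compound 3 `O=C(Nc1ccnnc1)c1cc(N2CCC(F)CC2)ccc1OCc1ccccc1`: 39.8 nM

All three numbers come from an assay on Sf9 cells for inhibition of Leucine-rich repeat serine/threonine-protein kinase 2 (Homo sapiens), read by TR-FRET, with stated times of 30 min and 2 h; on this read-out lower numbers stand for stronger inhibition and higher numbers for weaker inhibition. Among them compound 3 gives the highest number. Its nearest neighbour is compound 1, the step being a 1.6-fold higher number from compound 1 to compound 3 (0.20 log units; within the scatter); its furthest is compound 2, the step being a 2.5-fold higher number from compound 2 to compound 3 (0.40 log units; beyond the scatter). Compound 4 `O=C(Nc1ccnnc1)c1cc(N2CCCC2)ccc1OCc1ccccc1` has not yet been measured in this assay. It differs from compound 3 in one place: pyrrolidin-1-yl in place of 4-fluoropiperidin-1-yl on an aromatic carbon. Among the measured compounds shown here, no measured step involves pyrrolidin-1-yl, so the only guidance comes from the two steps that end at compound 3: a 1.6-fold higher number from compound 1 to compound 3 (0.20 log units; within the scatter) and a 2.5-fold higher number from compound 2 to compound 3 (0.40 log units; beyond the scatter). For the measured compounds named here, both show that exchanging the group at this aromatic carbon moves the number only a little, and the one change that went beyond the scatter was the one that introduced 4-fluoropiperidin-1-yl. Removing it is therefore expected to give in this assay a small step towards a lower number, or none beyond the scatter. For compound 4 the estimate is 28 nM, with a range from 12 nM to 70 nM. This estimate means an expected step of a 1.4-fold lower number from compound 3 to compound 4 (0.15 log units; within the scatter).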

Compound 4, half-maximal inhibitory concentration: 20 nM
For compound 4 the middle estimate is 1.4-fold (0.15 log units) above the measured one; low and high end bracket the measured number.
By their numbers in this assay, from the lowest: compounds 2, 4, 1 and 3 (each within the scatter of the next, the first and the last beyond it).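

In this assay, among the compounds shown here, pyrrolidin-1-yl at this aromatic carbon gives a 2.0-fold lower number from compound 3 to compound 4 (0.30 log units; within the scatter) and a 1.3-fold higher number from compound 2 to compound 4 (0.10 log units; within the scatter) and also a 1.3-fold lower number from compound 1 to compound 4 (0.10 log units; within the scatter) with no step to any of the three groups beyond the scatter. For the compounds shown here, compound 4 thus shows that a ring with a single nitrogen can stay within the scatter of compound 2, whereas compound 3, which also has a single ring nitrogen, goes against any simple link to that nitrogen, with a 2.5-fold higher number from compound 2 to compound 3 (0.40 log units; beyond the scatter) as the only step beyond it. Nothing given here explains these numbers.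

The compounds shown leave open whether an open-chain amine such as dimethylamino or a morpholin-4-yl group would stay within this narrow span. They also leave open whether a carboxylic acid on the pyrrolidine ring would be accepted at this position.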